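This account rests on a few compounds, and the source may have more. Where it says the series, first, only, none or still open, it means among the compounds named here.

Compound 1 `Cc1cc[n+]([O-])cc1Oc1ccccc1`: 30 mg/kg
Compound 2 `Cc1ccc(Oc2c[n+]([O-])ccc2C)cc1`: 300 mg/kg
Compound 3 `CC(C)c1cc[n+]([O-])cc1Oc1ccccc1`: 30 mg/kg

These three compounds were tested in a functional assay on the whole organism with Mus musculus as the target, in the maximal electroshock model, with a stated time of 30 min; on this read-out lower numbers stand for an effect already at smaller amounts and higher numbers for an effect only at larger amounts of compound. Compound 1 stands level with compound 3 at the digits printed, and the two together give the lowest numbers of the three; compound 2 lies furthest away, with a 10-fold higher number from compound 1 to compound 2 (1.00 log units; beyond the scatter).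

Compound 4 `CC(C)(C)c1cc[n+]([O-])cc1Oc1ccccc1` has not yet been measured. It differs from compound 1 in one place: tert-butyl in place of methyl on an aromatic carbon.

Of the measured steps, the one that bears on this change is the one in which a larger alkyl group took the place of methyl at the same position: no change at the digits printed from compound 1 to compound 3 (within the scatter). The step to compound 2 concerns a methyl added on the other ring and does not speak to the alkyl group here. Since enlarging methyl to isopropyl left the number where it was, a further enlargement to tert-butyl is expected to give no change at the digits printed from compound 1 to compound 4 (within the scatter), with no step beyond the scatter.

Compound 4 is therefore estimated at 30 mg/kg, with a range from 10 mg/kg to 100 mg/kg.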

Compound 4, minimum effective dose: 30 mg/kg
The estimate for compound 4 equals the measured number at the digits printed; low and high end bracket the measured number.
By their numbers in this assay, from the lowest: compounds 1, 3 and 4 (each within the scatter of the next); then compound 2.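

In this assay, the aromatic carbon opposite the ring nitrogen accepts tert-butyl as readily as methyl, with no change at the digits printed from compound 1 to compound 4 (within the scatter) in the number. The extra methyl that turns isopropyl into tert-butyl also leaves no change at the digits printed from compound 3 to compound 4 (within the scatter), so the flat result now extends across three alkyl groups of growing size rather than resting on a single step. No measurement is available to explain why the number holds steady across these groups.

As far as these compounds go, all three groups at this position are branched or small alkyl groups, so it remains open whether an amine, a carboxylic acid or a longer chain would give the same number. The compounds also leave open whether hydrogen alone at this carbon would match them.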